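The source may hold more compounds than are shown below. What is called first, only, known or untested is meant among the compounds shown, and "the series" means these compounds.

In an ADME assay (Rattus norvegicus) for inhibition (a lower number here means a stronger inhibitor, a higher number a weaker inhibitor), compound 1, `Cc1nc2c([nH]1)C(=O)/C(=N/c1ccc(Cl)cc1)C(Cl)=C2O`, gives 2800 nM; 2820 nM (2 entries), and compound 2, `Cc1nc2c([nH]1)C(=O)/C(=N/c1ccc(Cl)cc1Cl)C(Cl)=C2O`, gives 800 nM. Compound 3, `O=C1C=C(Nc2ccc(Cl)cc2)C(=O)c2[nH]c(-c3ccccn3)nc21`, stands at the highest number of the set in this assay, with 13000 nM, its nearest neighbour being compound 2 at a gap well beyond the usual scatter. Compound 4, `O=C1C=C(Nc2ccc(I)cc2)C(=O)c2[nH]c(-c3ccccn3)nc21`, is not yet measured there. It differs from compound 3 by iodo in place of chloro on an aromatic carbon. For the measured compounds named here, no measured pair shows this same change, so no step size is known; the change is small and a step no larger than the scatter is expected, in either direction. On that basis compound 4 is estimated at 10000 nM, within 4000 nM to 25000 nM, the expected step being a 1.3-fold lower number from compound 3 to compound 4 (0.11 log units; within the scatter).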

Compound 4, half-maximal inhibitory concentration: 20000 nM
Compound 4: the middle estimate sits 2.0-fold (0.30 log units) below what was measured; low and high end bracket the measured number.
By their numbers in this assay, from the lowest: compound 2; then compounds 3 and 4 (each within the scatter of the next).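

Iodo in place of chloro at this place on the aromatic ring gives a 1.5-fold higher number from compound 3 to compound 4 (0.19 log units; within the scatter) in this assay and so leaves compound 3 and compound 4 indistinguishable. For the compounds shown here, this is the first step read at this position, and it shows that exchanging these two halogens does not shift the number beyond the scatter. No available measurement bears on why the two readings sit so close. As far as these compounds go, whether an amine, a carboxylic acid or a methoxy group here would shift the number remains open, as does whether this same halogen exchange behaves alike on a different core.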